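Swapping One Five-Membered Ring for Another on a Salicylic Acid

The source may report more compounds than this note shows. Statements on the series, on what has been measured and on what is new or still open speak of the compounds shown alone.

Compound 1 `O=C(O)c1ccc(-c2cscn2)cc1O`: 70 mg/kg
Compound 2 `O=C(O)c1cc(-n2ccnc2)ccc1O`: 75 mg/kg
Compound 3 `O=C(O)c1cc(-c2ncccn2)ccc1O`: 100 mg/kg

All three compounds were tested in a functional assay on the whole organism for inhibition, with Rattus norvegicus as the target, read by paw edema; on this read-out lower numbers stand for an effect already at smaller amounts and higher numbers for an effect only at larger amounts of compound. In this assay compound 1 gives 70 mg/kg, compound 2 gives 75 mg/kg and compound 3 gives 100 mg/kg. On these numbers compound 2 lies between the other two, with compound 1 nearest and compound 3 furthest away, yet every gap among the three falls within the usual scatter of such measurements, so the three compounds cannot be told apart by this assay.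

The next compound is compound 4 `O=C(O)c1cc(-c2cocn2)ccc1O`. It differs from compound 2 in one place:

1,3-oxazol-4-yl in place of 1H-imidazol-1-yl on an aromatic carbon

Within the data shown here, no measured pair shows what such a swap of one five-membered aromatic ring with 2 hetero atoms for another does here. Since compounds 1, 2 and 3, which carry three different aromatic rings on the shared core, all sit within the scatter of one another, the step of a 1.1-fold higher number from compound 2 to compound 4 (0.03 log units; within the scatter) is expected to be none beyond the scatter. Compound 4 is therefore estimated to give 80 mg/kg, with a range from 45 mg/kg to 140 mg/kg.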

Compound 4, dose for half-maximal effect: 110 mg/kg
The estimate for compound 4 lay 1.4-fold (0.14 log units) below the measured number; measured number inside the range.
By their numbers in this assay, from the lowest: compounds 1, 2, 3 and 4 (each within the scatter of the next).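

The swap of 1H-imidazol-1-yl for 1,3-oxazol-4-yl, meta to the carboxy group and para to the hydroxy group, gives a 1.5-fold higher number from compound 2 to compound 4 (0.17 log units; within the scatter) in this assay on the shared core. Among these compounds, this is the first pair that differs in one place only, so it shows directly that these two five-membered aromatic rings with 2 hetero atoms cannot be told apart at this position, even though they are attached differently and one ring nitrogen is replaced by oxygen. No other measurement bears on this pair, so nothing here can explain the result.

Still open, on these data alone, is whether a group of another kind at this place, such as an amine or a longer carbon chain, would also stay within the scatter of compound 2. One pair also cannot show whether this swap would read the same elsewhere on the shared core.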